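Working notes: compound 3 to compound 4

The source may report more compounds than this note shows. Statements on the series, on what has been measured and on what is new or still open speak of the compounds shown alone.

Values in a functional assay on MCF7 cells (Homo sapiens) for antiproliferative activity, read by MTT assay, with a stated time of 72 h; a higher number here means a weaker inhibitor, a lower number a stronger inhibitor
- compound 1 `O=S(=O)(Oc1ccccc1Cl)C1CC2OC1C(c1ccc(/C=C/c3cc(O)cc(O)c3)cc1)=C2c1ccc(O)cc1` gives 40400 nM
- compound 2 `O=S(=O)(Oc1ccccc1C(F)(F)F)C1CC2OC1C(c1ccc(/C=C/c3cc(O)cc(O)c3)cc1)=C2c1ccc(O)cc1` gives 18300 nM
- compound 3 `O=S(=O)(Oc1ccc(-c2ccccc2)cc1)C1CC2OC1C(c1ccc(/C=C/c3cc(O)cc(O)c3)cc1)=C2c1ccc(O)cc1` gives 7800 nM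

Compound 3 has the lowest number of the three. Compound 4 `Cc1cccc(OS(=O)(=O)C2CC3OC2C(c2ccc(/C=C/c4cc(O)cc(O)c4)cc2)=C3c2ccc(O)cc2)c1` carries 3-methylphenyl in place of 4-phenylphenyl on an oxygen. The closest evidence is the replacement of 2-chlorophenyl and 2-(trifluoromethyl)phenyl by 4-phenylphenyl: a 5.2-fold lower number from compound 1 to compound 3 (0.71 log units; beyond the scatter) and a 2.3-fold lower number from compound 2 to compound 3 (0.37 log units; beyond the scatter). Both steps are modest. Read in reverse, they point to a higher number on leaving 4-phenylphenyl. The step of a 2.2-fold lower number from compound 1 to compound 2 (0.34 log units; beyond the scatter) shows that the choice of substituent on the phenyl ring also matters. Within the data shown here, no measured compound carries a methyl group. A modest rise is expected, an estimated 2.6-fold higher number from compound 3 to compound 4 (0.41 log units; beyond the scatter). Compound 4 is estimated at 20000 nM (expected range 9000 nM to 45000 nM).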

Compound 4, half-maximal inhibitory concentration: 16300 nM
Estimate against measurement, compound 4: 1.2-fold (0.09 log units) above; the range from low to high includes it.
By their numbers in this assay, from the lowest: compound 3; then compounds 4 and 2 (each within the scatter of the next); then compound 1.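

The step to 3-methylphenyl on the oxygen gives a 2.1-fold higher number from compound 3 to compound 4 (0.32 log units; beyond the scatter) and shows that 4-phenylphenyl also keeps its lower number against a third single-ring group. With a 1.1-fold lower number from compound 2 to compound 4 (0.05 log units; within the scatter) as the reading, 3-methylphenyl and 2-(trifluoromethyl)phenyl cannot be told apart, whereas a 2.5-fold lower number from compound 1 to compound 4 (0.39 log units; beyond the scatter) leaves 2-chlorophenyl with the higher number. Nothing available explains these differences.

On these data alone, how a phenyl ring bearing an amine or a carboxylic acid would compare remains open. So does the effect of a longer chain in place of methyl.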